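The source may hold more compounds than are shown below. What is called first, only, known or untested is meant among the compounds shown, and "the series" means these compounds.

In an ADME assay on RAW264.7 cells (Mus musculus) for cytotoxicity, read by MTT assay, with a stated time of 18 h (a higher number here means that more compound is tolerated, a lower number that less compound is tolerated), compound 1 `C=C1C(=O)OC[C@@H]1CCOC(=O)Nc1cccc(Br)c1` gives 17700 nM. Two relatives that carry other groups on the aromatic ring sit close by: compound 2 `C=C1C(=O)OC[C@H]1CCOC(=O)Nc1ccc(I)cc1` gives 12800 nM and compound 3 `C=C1C(=O)OC[C@H]1CCOC(=O)Nc1ccc(CCCC)cc1` gives 15900 nM. The one step among these that changes a single place, a 1.2-fold higher number from compound 2 to compound 3 (0.09 log units; within the scatter), stays within the scatter. Compound 1 thus stands among the three numbers without any gap beyond the scatter: its value and that of compound 3 lie within the scatter of each other, and so do its value and that of compound 2.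

Compound 4 `C=C1C(=O)OC[C@@H]1CCOC(=O)Nc1ccccc1` differs from compound 1 by hydrogen in place of bromo on an aromatic carbon. Among the compounds with values here, no measured step removes a halogen from this ring, so none bears directly on this change; the only single-place step, which swaps one aromatic substituent for another, was within the scatter. Compound 4 is therefore expected to show no step beyond the scatter in this assay, with an estimate of 16000 nM and a range from 8000 nM to 32000 nM. The expected step is a 1.1-fold lower number from compound 1 to compound 4 (0.04 log units; within the scatter).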

Compound 4, half-maximal cytotoxic concentration: 22300 nM
For compound 4 the middle estimate is 1.4-fold (0.14 log units) below the measured one; the range from low to high includes it.
By their numbers in this assay, from the lowest: compounds 2, 3, 1 and 4 (each within the scatter of the next).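

In this assay, hydrogen in place of bromo on an aromatic carbon, meta to a large group, gives a 1.3-fold higher number from compound 1 to compound 4 (0.10 log units; within the scatter). At this place on the ring of compound 1, the bromo can therefore be lost altogether without a step beyond the scatter, whereas the earlier single-place step only exchanged one aromatic substituent for another in a different pair of compounds. Nothing measured here offers an explanation for this result. The compounds shown leave open whether an amine, a carboxylic acid or a longer chain at this same place would also stay within the scatter. They also leave open whether taking the iodo off compound 2 would give a similarly small step.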